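Trimming a Cyclic Amine to Dimethylamino

A few compounds are considered here, and "the series" means these few. Any claim that something is new, unique, unknown or untested is made for them only; others in the source may bear on it.

Compound 1 `O=C(O)Cc1sc(C(c2ccc(F)cc2)c2ccc(F)cc2)nc1-c1ccnc(N2CCCC2)c1` was tested in an in vitro functional assay on HEK285-7 cells for antagonist activity at prostaglandin D2 receptor 2 (Homo sapiens), read by BRET and beta-arrestin recruitment (a higher number here means a larger maximal response, a lower number a smaller maximal response), and gives 80%. Compound 2 `O=C(O)Cc1sc(C(c2ccccc2)c2ccc(O)cc2)nc1-c1ccc(F)cc1`, which in this assay gives 80%, stands level with compound 1 within the scatter. Compound 3 `CN(C)c1cc(-c2nc(C(c3ccc(F)cc3)c3ccc(F)cc3)sc2CC(=O)O)ccn1` has not been measured. It differs from compound 1 by dimethylamino in place of pyrrolidin-1-yl on an aromatic carbon, a dimethylamino in place of pyrrolidin-1-yl on an aromatic carbon, next to the ring nitrogen. Among the measured compounds shown here, no measured step of this kind is available, so a change no larger than the scatter is expected. The expected step is a number 2 percentage points lower from compound 1 to compound 3 (within the scatter). Compound 3 is estimated at 78%, with a range from 65% to 92%.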

Compound 3, largest response reached (reported as efficacy), in percent of the reference or control that the assay uses: 80%
Compound 3: middle estimate off by 2 percentage points, on the low side; low and high end bracket the measured number.
By their numbers in this assay, from the lowest: compounds 1, 2 and 3 (each within the scatter of the next).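

Among the compounds shown here, replacing pyrrolidin-1-yl with dimethylamino on this aromatic carbon, next to the ring nitrogen, gives in this assay no change at the digits printed from compound 1 to compound 3 (within the scatter), the first reading of any change at this position. The ring of the pyrrolidin-1-yl group is therefore not required to hold the maximal response at this level, at least with the rest of compound 1 unchanged. Nothing available explains this result. Still open, going by these compounds, is how a morpholin-4-yl, a piperidin-1-yl or a primary amine would read here, and whether any amine is needed at this carbon.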